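From phenyl to 3-aminophenyl on an amide

A few compounds are considered here, and "the series" means these few. Any claim that something is new, unique, unknown or untested is made for them only; others in the source may bear on it.

Compound 1 `COc1ccc(S(=O)(=O)Nc2ccccc2CCc2ccc(C(=O)NO)cc2)cc1` reports only a limit in a functional assay on KB cells (Homo sapiens) for antiproliferative activity, read by sulforhodamine B assay, with a stated time of 48 h (on this read-out lower numbers stand for stronger inhibition of growth and higher numbers for weaker inhibition of growth), > 10000 nM. Compound 3 `COc1ccc(S(=O)(=O)Nc2ccccc2CCc2ccc(C(=O)Nc3ccccc3)cc2)cc1` gives a true number in this assay, 137 nM. The exchange of hydroxy for phenyl on an amide-type nitrogen is an at least 72-fold lower number from compound 1 to compound 3 (1.86 log units; beyond the scatter). Compound 2 `Nc1ccccc1NC(=O)c1ccc(CCc2ccccc2NS(=O)(=O)c2ccc(Br)cc2)cc1` gives 124 nM, within the scatter of compound 3, so the two stand level.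

Compound 4 `COc1ccc(S(=O)(=O)Nc2ccccc2CCc2ccc(C(=O)Nc3cccc(N)c3)cc2)cc1` turns the phenyl of compound 3 into 3-aminophenyl, with amino in place of hydrogen on an aromatic carbon. Among the compounds with values here, no measured step tests this change directly. Within the data shown here, the one large step replaced the whole group on that nitrogen, so it says little about a single added amino. Compound 2, which also bears amino on the phenyl of its amide, sits at 124 nM, although it differs elsewhere too. The step expected in this assay is therefore small, a 1.1-fold higher number from compound 3 to compound 4 (0.04 log units; within the scatter), with no move beyond the scatter foreseen. For compound 4 the estimated value is 150 nM, with an expected range of 40 nM to 600 nM.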

Compound 4, concentration for 50% growth inhibition: 697 nM
For compound 4 the middle estimate is 4.6-fold (0.67 log units) below the measured one, and the stated range ends below it.
By their numbers in this assay, from the lowest: compounds 2 and 3 (each within the scatter of the next); then compound 4. At a limit, above all of these: compound 1.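

Within the data shown here, on this phenyl, a single added amino counts for more than the earlier compounds could show: in this assay, amino in place of hydrogen on an aromatic carbon gives a 5.1-fold higher number from compound 3 to compound 4 (0.71 log units; beyond the scatter). The 3-aminophenyl group on the amide nitrogen still stands well apart from hydroxy, with an at least 14-fold lower number from compound 1 to compound 4 (1.15 log units; beyond the scatter). Compound 1 reports a limit and not a number, so that step gives only a bound: the limit of > 10000 nM in this assay, at which 1 of the 4 values shown sits.

The compounds shown leave open whether this rise belongs to amino itself or would also come with a hydroxy group, a methyl group or a fluorine on that same aromatic carbon. They also leave open whether amino on another carbon of this ring would give a step of the same size.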